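Working notes: extending the saturated chain once more

The source may report more compounds than this note shows. Statements on the series, on what has been measured and on what is new or still open speak of the compounds shown alone.

In a functional assay on L1210 cells (Mus musculus) for cytotoxicity, read by MTT assay, with a stated time of 48 h (on this read-out lower numbers stand for stronger inhibition and higher numbers for weaker inhibition), compound 1 `CCCCCCCCCCC(=O)c1cc(O)c(O)c(O)c1` gives 12200 nM and compound 2 `CCCCCCCCCCCC(=O)c1cc(O)c(O)c(O)c1` gives 11300 nM. Compound 2 therefore stands level with compound 1 on the two numbers available, and neither can be separated from the other.

The next compound is compound 3 `CCCCCCCCCCCCC(=O)c1cc(O)c(O)c(O)c1`, which keeps the shared core of compound 2 and differs only in the chain: methyl in place of hydrogen on a saturated chain carbon, ten or more bonds along the chain from a carbonyl carbon. This is methyl in place of hydrogen on a saturated chain carbon, ten or more bonds along the chain from a carbonyl carbon.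

Within the data shown here, one measured step bears on this change, since the same replacement links the first two compounds: a 1.1-fold lower number from compound 1 to compound 2 (0.03 log units; within the scatter). A single step is thin evidence, and the data do not show how far this pattern extends along the chain. On that basis, no step beyond the scatter is expected in this assay.

The estimated step is a 1.0-fold lower number from compound 2 to compound 3 (0.01 log units; within the scatter). For compound 3 the expected value is 11000 nM, with an expected range of 5500 nM to 23000 nM.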

Compound 3, half-maximal inhibitory concentration: 10900 nM
For compound 3 the middle estimate is 1.0-fold (0.00 log units) above the measured one; the measured number falls inside the stated range.
By their numbers in this assay, from the lowest: compounds 3, 2 and 1 (each within the scatter of the next).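

In this assay, the second extension of the chain gives a 1.0-fold lower number from compound 2 to compound 3 (0.02 log units; within the scatter), so methyl in place of hydrogen on a saturated chain carbon, ten or more bonds along the chain from a carbonyl carbon, has now stayed within the scatter twice rather than once. Read over both extensions together, ethyl in place of hydrogen gives a 1.1-fold lower number from compound 1 to compound 3 (0.05 log units; within the scatter), which shows that even the larger change stays within the scatter and that the three compounds cannot be separated on this read-out. Nothing measured alongside these numbers accounts for the absence of a visible step.

The compounds shown leave open whether this level run holds for a longer chain or for a much shorter one, since all three numbers come from one narrow stretch of chain lengths. They also leave open what a group of a different kind at the far end of the chain, such as an amine or a carboxylic acid, would do to the number in this assay.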